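Cyclopropyl for but-1-yn-1-yl on the shared core

This account rests on a few compounds, and the source may have more. Where it says the series, first, only, none or still open, it means among the compounds named here.

Measured so far:
compound 1, `C#CC[C@@]1(O)[C@@H](CO)O[C@@H](n2ccc(=O)[nH]c2=O)[C@@H]1O`: in a functional assay on L1210 cells (Mus musculus), read by MTT assay (a lower number here means a stronger inhibitor, a higher number a weaker inhibitor), compound 1 gives > 350000 nM, a limit of the assay and not a number.
compound 2, `CCC#C[C@@]1(O)[C@@H](CO)O[C@@H](n2ccc(=O)[nH]c2=O)[C@@H]1O`: in this assay compound 2 gives 338000 nM.
compound 3, `CCC#C[C@@]1(O)[C@@H](CO)O[C@@H](n2ccc(N)nc2=O)[C@@H]1O`: in this assay compound 3 gives 129000 nM.

Compound 2 holds the highest of the two numbers in this assay; the nearest is compound 3, whose number lies lower by a gap beyond the scatter. Compound 1 sits at the limit of > 350000 nM in this assay, at which 1 of the 3 values shown sits.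

The next compound is compound 4, `O=c1ccn([C@@H]2O[C@H](CO)[C@](O)(C3CC3)[C@H]2O)c(=O)[nH]1`. It differs from compound 2 in one place: cyclopropyl in place of but-1-yn-1-yl on a saturated ring carbon.

Going by the values given here, one measured step touches the same saturated ring carbon: an at least 1.0-fold lower number from compound 1 to compound 2 (0.01 log units; that floor lies within the scatter). That exchange of one small carbon group for another left the number within the scatter. Among the compounds with values here, no measured step exchanges a chain with a triple bond for a three-membered ring, so the present change is weighed mainly by that single step. The expected outcome for compound 4 in this assay is a step of about a 1.0-fold lower number from compound 2 to compound 4 (0.01 log units; within the scatter), staying within the scatter in no firm direction, with a real chance that only a limit is reported. Compound 4 is estimated at 330000 nM, with a range of 150000 nM to 700000 nM.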

Compound 4, half-maximal inhibitory concentration: > 350000 nM
Compound 4: no number, only a limit; the forecaster's own chance of this, stated with the estimate: 45%; middle value at least 1.0-fold (0.02 log units) from the limit.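

In this assay compound 4 gives > 350000 nM, a limit of the assay and not a number. Replacing the triple-bond chain with a three-membered ring on this saturated ring carbon gives an at least 1.0-fold higher number from compound 2 to compound 4 (0.01 log units; that floor lies within the scatter), so this change brings no readable gain, and the step between the two limits, from compound 1 to compound 4, cannot be read. Propargyl, but-1-yn-1-yl and cyclopropyl at this position have so far produced no readable step beyond the scatter, and the values gather at one end of the range: the limit of > 350000 nM in this assay, at which 2 of the 4 values shown sit.

Going by these compounds alone, it remains open whether the change in the one place where compound 3 differs from compound 2, with compound 3 at 129000 nM, would also lower the number when paired with cyclopropyl. The compounds shown also leave open whether an amine, a carboxylic acid or a longer chain on this saturated ring carbon would bring a value clearly below the limit.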